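Swapping the pyridine attachment point on a fused thiophene core

The source may report more compounds than this note shows. Statements on the series, on what has been measured and on what is new or still open speak of the compounds shown alone.

Compound 1: `COc1cccc(CN2CCc3cc(-c4ccc5[nH]ncc5c4)ccc3C2=O)c1` — 2060 nM in an assay on isolated protein for inhibition of Rho-associated protein kinase 1 (Homo sapiens), read by radiometric assay and 33P incorporation, with a stated time of 40 min, in the presence of a further agent that is not named here; a lower number here means a stronger inhibitor, a higher number a weaker inhibitor
Compound 2: `COc1cccc(Cn2cnc3sc(-c4ccc5[nH]ncc5c4)cc3c2=O)c1` — this assay: 20 nM
Compound 3: `COc1cccc(Cn2cnc3sc(-c4ccncc4)cc3c2=O)c1` — this assay: 45 nM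

Compound 3 stands second of the three numbers in this assay: its nearest neighbour is compound 2, with the step of a 2.3-fold higher number from compound 2 to compound 3 (0.35 log units; beyond the scatter), while compound 1 lies far away at the weak end of the set. Compound 4 has the structure `COc1cccc(Cn2cnc3sc(-c4cccnc4)cc3c2=O)c1`. It differs from compound 3 in a single place: pyridin-3-yl in place of pyridin-4-yl on an aromatic carbon. Within the data shown here, no measured pair covers this exact change; the only step that touches the same aromatic carbon is the one from compound 2 to compound 3, which shows that the group there moves the number by a modest amount. Because that step a 2.3-fold higher number from compound 2 to compound 3 (0.35 log units; beyond the scatter) was modest, and because the change to compound 4 keeps the same atoms in a different arrangement, a larger shift cannot be excluded but is not demanded by the data. Compound 4 is expected to give a weaker number than compound 3, with the estimated step of a 6.7-fold higher number from compound 3 to compound 4 (0.82 log units; beyond the scatter). Compound 4 is estimated at 300 nM, with a range from 60 nM to 1500 nM.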

Compound 4, half-maximal inhibitory concentration: > 10000 nM
Compound 4: no number, only a limit (the forecaster's own chance of this, stated with the estimate: 5%); middle value at least 33-fold (1.52 log units) away from the limit.
By their numbers in this assay, from the lowest: compound 2; then compound 3; then compound 1. At a limit, above all of these: compound 4.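

Compound 4 gives no number, only a limit of the assay: the limit of > 10000 nM in this assay, at which 1 of the 4 values shown sits. Exchanging pyridin-4-yl for pyridin-3-yl on the aromatic carbon next to the ring sulfur keeps the same atoms, yet it gives an at least 220-fold higher number from compound 3 to compound 4 (2.34 log units; beyond the scatter), a large step where the earlier 2.3-fold higher number from compound 2 to compound 3 (0.35 log units; beyond the scatter) was modest, so at this position the arrangement of the atoms in the group matters far more than the earlier pair showed. Measured against 1H-indazol-5-yl, pyridin-3-yl gives an at least 500-fold higher number from compound 2 to compound 4 (2.69 log units; beyond the scatter).

The compounds shown give no measured cause for this loss, and the limit leaves the true size of both steps unknown. They also leave open how a pyridin-2-yl or a plain phenyl group would fare on this carbon.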